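Same Replacement on a Second Core

This account rests on a few compounds, and the source may have more. Where it says the series, first, only, none or still open, it means among the compounds named here.

The study compares four compounds built on two related cores, all tested in a functional assay on SW480 cells (Homo sapiens) for antiproliferative activity; a lower number here means a stronger inhibitor, a higher number a weaker inhibitor. Compound 1 `COc1ccccc1/C=C/C(=O)c1ccc(OCCn2cc(CN3C(=O)/C=C/C(C)(C)C/C=C(\C)CC/C=C/3C)nn2)cc1O` gives 0.9 ug/mL in this assay. Compound 2 `COc1cc(/C=C/C(=O)c2ccc(OCCn3cc(CN4C(=O)/C=C/C(C)(C)C/C=C(\C)CC/C=C/4C)nn3)cc2O)cc(OC)c1OC` carries the change 3,4,5-trimethoxyphenyl in place of 2-methoxyphenyl on a double-bonded chain carbon bound to a double-bonded chain carbon and in this assay compound 2 gives 2.61 ug/mL; the step of a 2.9-fold higher number from compound 1 to compound 2 (0.46 log units; beyond the scatter) lies beyond the scatter. Compound 3 `COc1ccccc1/C=C/C(=O)c1ccc(OCCCN2C(=O)/C=C/C(C)(C)C/C=C(\C)CC/C=C/2C)cc1` rests on a second core, and the difference between the two cores is not broken down here. In this assay compound 3 gives 1.33 ug/mL, a number that sits within the scatter of both compound 1 and compound 2, so compound 3 cannot be told apart from either of them on these data.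

Compound 4 `COc1cc(/C=C/C(=O)c2ccc(OCCCN3C(=O)/C=C/C(C)(C)C/C=C(\C)CC/C=C/3C)cc2)cc(OC)c1OC` has not been measured. It differs from compound 3 by 3,4,5-trimethoxyphenyl in place of 2-methoxyphenyl on a double-bonded chain carbon bound to a double-bonded chain carbon, the same change that separates compound 1 from compound 2; the change occurs twice among the compounds shown, at the same place in both cases. Within the data shown here, the single measured step is the only guide to what it does on the second core. If the second core answers in the same way, the step from compound 3 to compound 4 is expected to be a 2.9-fold higher number from compound 3 to compound 4 (0.46 log units; beyond the scatter) in this assay, set beside the measured 2.9-fold higher number from compound 1 to compound 2 (0.46 log units; beyond the scatter). Compound 4 is therefore estimated at 3.8 ug/mL, with a range from 1.7 ug/mL to 8.5 ug/mL; the range is kept wide, as one step on another core is a thin base.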

Compound 4, half-maximal inhibitory concentration: 0.71 ug/mL
Beside the measured number, compound 4's estimate is 5.4-fold (0.73 log units) above it, and the stated range ends above it.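

In this assay, 3,4,5-trimethoxyphenyl in place of 2-methoxyphenyl on the second core gives a 1.9-fold lower number from compound 3 to compound 4 (0.27 log units; within the scatter), so the two compounds on that core cannot be told apart. The same change therefore does not keep its size when it is carried from one core to the other: the same change on two cores in this assay, a 2.9-fold higher number (0.46 log units; beyond the scatter) from compound 1 to compound 2 and a 1.9-fold lower number (0.27 log units; within the scatter) from compound 3 to compound 4, 5.4-fold (0.73 log units) apart, beyond the scatter of two such steps. Among these compounds, this shows that the step measured on the core of compound 1 cannot be applied as a fixed increment to the core of compound 3, but it does not show what causes the difference, and with only one pair on each core it says nothing about how the change would behave on any further core.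

The compounds shown leave open which part of the difference between the two cores decides the outcome, as compound 1 and compound 3 differ in more than one place and no compound here separates those differences. They also leave open how other groups on the same double-bonded chain carbon, such as an unsubstituted phenyl or a phenyl carrying an amine, would fare on each of the two cores.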